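A few compounds are considered here, and "the series" means these few. Any claim that something is new, unique, unknown or untested is made for them only; others in the source may bear on it.

Measured in a physicochemical assay for solubility, with a stated time of 24 h, tested at 30 mg/mL; a lower number here means a less soluble compound, a higher number a more soluble compound:
- Compound 1 `O=C(CCCCCNc1c(Nc2ccccc2)c(=O)c1=O)NO`: 2200000 nM
- Compound 2 `C[C@@H](Nc1c(NCCCCCC(=O)NO)c(=O)c1=O)c1ccccc1`: 39000000 nM
- Compound 3 `CC(CCCCC(=O)NO)Nc1c(Nc2ccccc2)c(=O)c1=O`: 46000000 nM

Compound 3 and compound 2 share the top of this small set, within the scatter of each other, while compound 1 lies well under both. Compound 4 `CC(CCCCC(=O)NO)Nc1c(Nc2ccc(C(F)(F)F)cc2)c(=O)c1=O` differs from compound 3 in one place: trifluoromethyl in place of hydrogen on an aromatic carbon.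

Among the compounds with values here, no measured step covers this change directly. The closest guides are an 18-fold higher number from compound 1 to compound 2 (1.25 log units; beyond the scatter), with 1-phenylethyl in place of phenyl on a nitrogen on an aromatic ring, and a 21-fold higher number from compound 1 to compound 3 (1.32 log units; beyond the scatter), with methyl in place of hydrogen on a saturated chain carbon. Both steps are large, so a single change can move this assay a long way, but both lie elsewhere in the structure and neither fixes a size for this one. With compound 3 at 46000000 nM, already level with the top of the set, a fall is expected rather than a rise, and it is expected to reach beyond the scatter. The estimated step is a 4.6-fold lower number from compound 3 to compound 4 (0.66 log units; beyond the scatter). For compound 4 the estimated value is 10000000 nM, with an expected range of 2000000 nM to 40000000 nM.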

Compound 4, solubility: 20000000 nM
Compound 4: the middle estimate sits 2.0-fold (0.30 log units) below what was measured; the measured number falls inside the stated range.
By their numbers in this assay, from the lowest: compound 1; then compounds 4, 2 and 3 (each within the scatter of the next, the first and the last beyond it).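

In this assay, putting trifluoromethyl in place of hydrogen on an aromatic carbon, para to a large group, gives a 2.3-fold lower number from compound 3 to compound 4 (0.36 log units; beyond the scatter) and is the first step shown that alters only an aromatic carbon and leaves the rest of the structure untouched. The earlier steps shown here, an 18-fold higher number from compound 1 to compound 2 (1.25 log units; beyond the scatter) and a 21-fold higher number from compound 1 to compound 3 (1.32 log units; beyond the scatter), are both large, whereas this one is modest, so within these few compounds a change at this position moves the number a shorter way than either of those changes elsewhere in the structure, though still beyond the scatter. Nothing available explains why the number falls with this group, and the step stands as a description of the numbers alone.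

As far as these compounds go, what a nitrile, a methoxy group or a carboxylic acid would do at this same aromatic carbon remains open, as does whether a lone fluorine would move the number in the same direction. From the compounds shown here alone, it is also open whether trifluoromethyl at this position would give a step of similar size on compound 1 or compound 2, or on a compound with a longer chain.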